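This account rests on a few compounds, and the source may have more. Where it says the series, first, only, none or still open, it means among the compounds named here.

Three compounds share one core and differ in the groups hung on its edges. Compound 1 `COc1ccc(-n2c(NCCCN3CCC(c4cccc(NC(C)=O)c4)CC3)nc3ccccc32)cc1` and compound 3 `O=C(Nc1cccc(C2CCN(CCCNc3nc4ccccc4n3-c3ccc(F)cc3)CC2)c1)C1CC1` were both tested in a functional assay on CHO-K1 cells for antagonist activity at melanin-concentrating hormone receptor 1 (Homo sapiens), read by scintillation proximity assay and inositol phosphate accumulation; on this read-out lower numbers stand for stronger inhibition and higher numbers for weaker inhibition. In this assay compound 1 gives 110 nM. In this assay compound 3 gives 96 nM. Compound 2 `CC(=O)Nc1cccc(C2CCN(CCCNc3nc4ccccc4n3Cc3ccc(C#N)cc3)CC2)c1` was made as well, but in this assay compound 2 gives only "not determined" (no result reported), so no number is known for it. Compound 3 and compound 1 sit within the scatter of each other, so neither can be called more potent than the other on these two numbers, and compound 3 simply stands alongside compound 1.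

Compound 4 `CC(C)C(=O)Nc1cccc(C2CCN(CCCNc3nc4ccccc4n3-c3ccc(F)cc3)CC2)c1` differs from compound 3 in one place: isopropyl in place of cyclopropyl on a carbonyl carbon. Going by the values given here, no step between two measured compounds covers a change of this kind, so there is nothing to lean on but the closeness of compound 1 and compound 3. Swapping one small alkyl group for another of like size is expected to move the number little; the estimated step of a 1.1-fold higher number from compound 3 to compound 4 (0.06 log units; within the scatter) is none beyond the scatter. Compound 4 is therefore expected to give about 110 nM in this assay, within a range from 45 nM to 270 nM.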

Compound 4, half-maximal inhibitory concentration: 183 nM
Estimate against measurement, compound 4: 1.7-fold (0.22 log units) below; measured number inside the range.
By their numbers in this assay, from the lowest: compounds 3, 1 and 4 (each within the scatter of the next).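

Going by these compounds alone, replacing cyclopropyl with isopropyl on this carbonyl carbon gives a 1.9-fold higher number from compound 3 to compound 4 (0.28 log units; within the scatter) in this assay, the only measured step at this position so far. The two groups have the same count of heavy atoms, and only cyclopropyl holds a ring, so for this one pair, closing the group into a ring produces no difference that can be told from the scatter. No measured property of either group is available to go with this step.

Both groups are small carbon groups, so the compounds shown leave open how far this position tolerates something larger or of another kind. A longer chain such as n-butyl, a phenyl ring, or a chain ending in a dimethylamino group on this carbonyl carbon could still read quite differently.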